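A few compounds are considered here, and "the series" means these few. Any claim that something is new, unique, unknown or untested is made for them only; others in the source may bear on it.

In a functional assay on A2780 cells (Homo sapiens) for inhibition, with a stated time of 72 h, tested at 10 uM (on this read-out lower numbers stand for less inhibition of growth and higher numbers for more inhibition of growth at the one concentration tested), three compounds have been measured. Compound 1 `CC1(C)CCOc2ccc(NC(=O)Nc3ccc([N+](=O)[O-])cc3)cc21` gives 74%. Compound 2 `CCC1(CC)CC(CC)(CC)c2cc(NC(=O)Nc3ccc(C(F)(F)F)cc3)ccc2O1` gives 86.2%, the second highest of the three numbers. Compound 3 `CC1(C)CC(C)(C)c2cc(N/C(S)=N/c3ccc([N+](=O)[O-])cc3)ccc2O1` gives 87%, which lies within the scatter of compound 2, while the number for compound 1 lies beyond it, lower. Compound 4 `CCC1(CC)CC(CC)(CC)c2cc(NC(=O)Nc3ccc([N+](=O)[O-])cc3)ccc2O1` keeps the core of compound 2 and differs from it only at one place: nitro in place of trifluoromethyl on an aromatic carbon. Going by the values given here, no measured pair shows this exact change on this core, so the size of the step is open; compound 1 and compound 3, which both carry the nitro group, give neither a clearly lower nor a clearly higher picture. Compound 4 is therefore expected to stay close to compound 2, with the step from compound 2 to compound 4 estimated at a number 4.2 percentage points lower from compound 2 to compound 4 (within the scatter), no more than the scatter. The estimate for compound 4 in this assay is 82%, expected between 68% and 93%.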

Compound 4, percent growth inhibition at one concentration: 91.4%
The estimate for compound 4 lay 9.4 percentage points below the measured number; the range from low to high includes it.
By their numbers in this assay, from the lowest: compound 1; then compounds 2, 3 and 4 (each within the scatter of the next).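

In this assay the change from trifluoromethyl to nitro on this aromatic carbon, para to a large group, now has a direct reading, a number 5.2 percentage points higher from compound 2 to compound 4 (within the scatter), so on this core the two groups are not separated at the one concentration tested. Nothing at hand gives a reason for this result. Going by these compounds, whether an amine, a nitrile or a carboxylic acid on this carbon would read the same stays open. So does whether the two groups would stay level at concentrations other than the one tested.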